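Aryl exchange on the amide nitrogen of compound 1

The compounds below may be only part of what the source reports. "The series", "measured", "known", "first", "only" and "open" are said of these compounds alone.

In a functional assay on A549 cells (Homo sapiens) for cytotoxicity, read by MTT assay, with a stated time of 72 h (on this read-out lower numbers stand for stronger inhibition and higher numbers for weaker inhibition), compound 1 (`O=C(CN1CCN(c2nnc(Cc3ccncc3)c3ccccc23)CC1)Nc1cccc(F)c1`) gives 4600 nM. This lies within the scatter of compound 3 (`Cc1cccc(Cl)c1NC(=O)CN1CCN(c2nnc(Cc3ccccc3)c3ccccc23)CC1`) at 7420 nM. The gap to compound 2 (`O=C(CN1CCN(c2nnc(Cc3ccccc3)c3ccccc23)CC1)Nc1ccc(Br)cc1`) at 2000 nM is beyond the scatter, with compound 2 holding the lowest number of the three.

Compound 4 (`O=C(CN1CCN(c2nnc(Cc3ccncc3)c3ccccc23)CC1)Nc1cc(C(F)(F)F)ccc1Cl`) departs from compound 1 by 2-chloro-5-(trifluoromethyl)phenyl in place of 3-fluorophenyl on an amide-type nitrogen.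

For the measured compounds named here, only one measured step touches this place, a 3.7-fold higher number from compound 2 to compound 3 (0.57 log units; beyond the scatter), and it is modest. Going by the values given here, compounds 2 and 3 also differ from compound 1 elsewhere in the structure, and no measured compound carries the entering group, so this step offers only a loose guide to size and none to direction. No clear shift is therefore expected. The expected step in this assay is a 1.2-fold lower number from compound 1 to compound 4 (0.06 log units; within the scatter), which would stay within the scatter. For compound 4 the estimated value is 4000 nM, with an expected range from 1500 nM to 9500 nM.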

Compound 4, half-maximal inhibitory concentration: 1850 nM
The estimate for compound 4 lay 2.2-fold (0.33 log units) above the measured number; low and high end bracket the measured number.
By their numbers in this assay, from the lowest: compounds 4 and 2 (each within the scatter of the next); then compounds 1 and 3 (each within the scatter of the next).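

In this assay the aryl exchange gives a 2.5-fold lower number from compound 1 to compound 4 (0.40 log units; beyond the scatter), so on the background of compound 1 this place on the amide-type nitrogen can move the number beyond the scatter, here downward. For the compounds shown here, the only earlier step at this place, a 3.7-fold higher number from compound 2 to compound 3 (0.57 log units; beyond the scatter), went upward on a different background. Both steps are modest and share neither a leaving nor an entering group, so no rule for this place follows, and nothing available accounts for the shift.

Still open, as far as these compounds go, is how much of the step belongs to the chlorine and how much to the trifluoromethyl, and whether the same exchange gives a similar step on the background of compounds 2 and 3. Also open, from the compounds shown here alone, is how the number responds to an amine or a carboxylic acid on the aryl ring, or to cyclohexyl in its place.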